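Adding One More Fluoro to Compound 1

This account rests on a few compounds, and the source may have more. Where it says the series, first, only, none or still open, it means among the compounds named here.

compound 1 (`COc1ccc(NS(=O)(=O)c2cc(F)c(F)c(F)c2F)cc1`) gives 400 nM
compound 2 (`COc1ccc(NS(=O)(=O)c2cc(F)c(Cl)c(F)c2F)cc1`) gives 22000 nM
compound 3 (`COc1ccc(NS(=O)(=O)c2cc(F)c(F)c(F)c2)cc1`) gives 3400 nM

In a functional assay on NCI/ADR-RES cells (Homo sapiens) for cytotoxicity (on this read-out higher numbers stand for weaker inhibition of growth and lower numbers for stronger inhibition of growth), compound 1 has the lowest number of these three (400 nM). Compound 4 (`COc1ccc(NS(=O)(=O)c2c(F)c(F)c(F)c(F)c2F)cc1`) has not yet been measured. It carries fluoro in place of hydrogen on an aromatic carbon.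

For the measured compounds named here, two measured steps bear on this change. Hydrogen in place of fluoro is the reverse kind of swap, and it gave a modest step (an 8.5-fold higher number from compound 1 to compound 3 (0.93 log units; beyond the scatter)). Chloro in place of fluoro gave a large step (a 55-fold higher number from compound 1 to compound 2 (1.74 log units; beyond the scatter)), so a single atom can move the number a long way in this small set. Going by the values given here, no measured compound has fluoro on this particular carbon, so the reverse swap is only a rough guide and the range must stay wide.

A modest drop in the number, meaning stronger inhibition of growth, is expected (a 2.7-fold lower number from compound 1 to compound 4 (0.43 log units; beyond the scatter)). For compound 4 the estimated value is 150 nM (expected range 30 nM to 800 nM).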

Compound 4, concentration for 50% growth inhibition: 58 nM
Estimate against measurement, compound 4: 2.6-fold (0.41 log units) above; measured number inside the range.
By their numbers in this assay, from the lowest: compound 4; then compound 1; then compound 3; then compound 2.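

In this assay, fluoro in place of hydrogen on the aromatic carbon ortho to a large group gives a 6.9-fold lower number from compound 1 to compound 4 (0.84 log units; beyond the scatter), so this carbon accepts fluoro and the hydrogen of compound 1 is not needed for growth inhibition. Read together with an 8.5-fold higher number from compound 1 to compound 3 (0.93 log units; beyond the scatter), which removes a fluoro from a different carbon, the number falls as fluoro is added and rises as fluoro is removed in these compounds, while compound 2 shows that chloro in place of fluoro on yet another carbon goes the opposite way from compound 4. Nothing measured here accounts for this gain in strength.

The compounds shown leave open whether chloro, methyl or an amine on this carbon would give a number as low as fluoro does. They also leave open whether the methoxy group could be exchanged for another group, such as a carboxylic acid, while keeping this gain.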